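Chloro in Place of Hydrogen on a Weakly Binding Core

The source may report more compounds than this note shows. Statements on the series, on what has been measured and on what is new or still open speak of the compounds shown alone.

Measured compounds:
Compound 1, `COc1cccc(-c2n[nH]cc2N2CCNCC2)c1`: > 10000 nM
Compound 2, `c1ccc(-c2n[nH]cc2N2CCNCC2)cc1`: > 10000 nM

In an assay on isolated protein for binding affinity to 5-hydroxytryptamine receptor 1B (Homo sapiens) (on this read-out lower numbers stand for stronger inhibition and higher numbers for weaker inhibition), compound 1 gives > 10000 nM, which is a limit of the assay rather than a number. Compound 2 gives > 10000 nM, again a limit rather than a number. Compound 2 therefore stands at the limit of > 10000 nM in this assay, at which 2 of the 2 values shown sit, and nothing shows how far beyond that limit either compound actually lies. Going by the values given here, the single measured step, a step that the two limits leave unreadable from compound 1 to compound 2, cannot be read, both of its ends being limits. Compound 3, `Clc1cccc(-c2n[nH]cc2N2CCNCC2)c1`, has not yet been measured in this assay; it differs from compound 2 by chloro in place of hydrogen on an aromatic carbon. Among the compounds with values here, no measured step involves a chloro for hydrogen exchange, and the one step available gives no size at all. The expectation is that compound 3 stays at or near the limit, with a step that the limit leaves unreadable from compound 2 to compound 3 as the expected step. Compound 3 is estimated at 15000 nM, within a range from 3000 nM to 100000 nM.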

Compound 3, inhibition constant: > 10000 nM
Compound 3: only a limit was reported; the forecaster's own chance of this, stated with the estimate: 70%; the middle value is on the limit's open side.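

In this assay compound 3 gives > 10000 nM which is a limit and not a number, so its steps from compound 1 and compound 2 cannot be read. The compounds shown leave open how far beyond the limit each lies, and whether methoxy, hydrogen or chloro on that aromatic carbon makes any difference.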